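A move from 4-chlorophenyl to 3-chlorophenyl

The source may hold more compounds than are shown below. What is called first, only, known or untested is meant among the compounds shown, and "the series" means these compounds.

Going by the values given here, in a functional assay on NCI-H1299 cells (Homo sapiens) for cytotoxicity, read by a luciferase reporter and CellTiter-Glo, with a stated time of 72 h (a higher number here means a weaker inhibitor, a lower number a stronger inhibitor), compound 1 (`COc1ccc(C2=NN(c3ccccc3Cl)C(c3cccc(Cl)c3)C2)cc1`) gives 7200 nM and is the only compound with a number. Compound 2 (`COc1cccc(C2=NN(c3ccccc3Cl)C(c3cccc(Cl)c3)C2)c1`) stands at "not determined" (no result reported) in this assay and offers no comparison. Compound 3 (`COc1ccccc1C1=NN(c2ccccc2Cl)C(c2ccc(Cl)cc2)C1`) likewise stands at "not determined" (no result reported) in this assay and so holds no place on the scale. Compound 4 (`COc1ccccc1C1=NN(c2ccccc2Cl)C(c2cccc(Cl)c2)C1`) is reached by one change: 3-chlorophenyl in place of 4-chlorophenyl on a saturated ring carbon with 3-chlorophenyl in place of 4-chlorophenyl on a saturated ring carbon. Among the compounds with values here, it thereby shares the 3-chlorophenyl of compound 1, whose 7200 nM is the sole guide. No measured step sizes this change, so in this assay no shift beyond the scatter is expected, in either direction. For compound 4 the estimated value is 7000 nM with 2500 nM to 20000 nM as its expected range.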

Compound 4, half-maximal inhibitory concentration: 13400 nM
The estimate for compound 4 lay 1.9-fold (0.28 log units) below the measured number, and the stated range covers the measured number.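

In this assay, the step shows a 1.9-fold higher number from compound 1 to compound 4 (0.27 log units; within the scatter), so with 3-chlorophenyl on the saturated ring carbon, 2-methoxyphenyl and 4-methoxyphenyl on the carbon with a double bond to nitrogen cannot be told apart. The move from 4-chlorophenyl to 3-chlorophenyl itself cannot be read, since compound 3 holds no number. No measurement shown here offers an explanation for these results.

On these data alone, the size of that chlorophenyl move therefore stays open. So does what an amine or a carboxylic acid in place of the methoxy group would do in this series.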